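From Nitro to Amino on the Chlorinated Compound

The source may hold more compounds than are shown below. What is called first, only, known or untested is meant among the compounds shown, and "the series" means these compounds.

In a functional assay on CCRF-CEM cells (Homo sapiens) for antiproliferative activity, with a stated time of 72 h (a higher number here means a weaker inhibitor, a lower number a stronger inhibitor), compound 1 (`COc1ccc(-n2c(-c3cc(OC)c(OC)c(OC)c3)csc2=O)cc1[N+](=O)[O-]`) gives 2700 nM. Compound 2 (`COc1ccc(-n2c(-c3cc(OC)c(OC)c(OC)c3)c(Cl)sc2=O)cc1[N+](=O)[O-]`) gives > 20000 nM, which is a limit of the assay and not a number. Going by the values given here, the only measured step is an at least 7.4-fold higher number from compound 1 to compound 2 (0.86 log units; beyond the scatter), with chloro in place of hydrogen on an aromatic carbon.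

Compound 3 (`COc1ccc(-n2c(-c3cc(OC)c(OC)c(OC)c3)c(Cl)sc2=O)cc1N`) departs from compound 2 by amino in place of nitro on an aromatic carbon, ortho to a methoxy group. Among the compounds with values here, no measured step makes this exchange, so the one step available bears on it only indirectly, by showing where compound 2 begins. Compound 1, at 2700 nM, shows that a nitro compound with this shared core can return a number. A step towards a lower number, beyond the scatter, is therefore expected in this assay, though its size is poorly constrained and compound 3 could still reach the limit. The expected step is an at least 25-fold lower number from compound 2 to compound 3 (1.39 log units; beyond the scatter). For compound 3 the estimated value is 800 nM, with an expected range from 50 nM to 12000 nM.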

Compound 3, half-maximal inhibitory concentration: 16200 nM
For compound 3 the middle estimate is 20-fold (1.31 log units) below the measured one, and the stated range ends below it.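

In this assay, the change from nitro to amino on this aromatic carbon, ortho to a methoxy group, is read as an at least 1.2-fold lower number from compound 2 to compound 3 (0.09 log units; that floor lies within the scatter). Compound 2 gives > 20000 nM, which is a limit of the assay and not a number. Compound 3 gives 16200 nM, so with amino at this position the chlorinated shared core now returns a measured value, something the earlier compounds had not shown. The true size of the step cannot be fixed and only its floor can be read because one end of it rests on a limit: the limit of > 20000 nM in this assay, at which 1 of the 3 values shown sits.

The compounds shown leave open what amino does on the core of compound 1, without the chloro, and so whether the exchange of nitro for amino has a larger effect there than can be read here. Going by these compounds, it also stays open whether another group at this position, such as a hydroxyl, an acetamide or a dimethylamino group, or a methyl or bromo in place of the chloro, would bring the number in this assay lower.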